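The source may report more compounds than this note shows. Statements on the series, on what has been measured and on what is new or still open speak of the compounds shown alone.

compound 1 `Cc1ccc(S(=O)(=O)N(Cc2cccc(F)c2F)Cc2cn(S(=O)(=O)c3ccc(C)cc3)c3ccccc23)cc1`: -13.9%
compound 2 `O=S(=O)(c1ccc(F)cc1)N(Cc1cccc(F)c1F)Cc1cn(S(=O)(=O)c2ccc(F)cc2)c2ccccc12`: -20%

Among the compounds with values here, in a functional assay on 3T3-L1 cells (Mus musculus) for inhibition, with a stated time of 20 min, tested at 20 uM (a lower number here means less inhibition, a higher number more inhibition at the concentration tested (going by the name of the read-out)), compound 2 gives -20%, the lowest of the two numbers so far; compound 1 gives -13.9%, a number within the scatter of the first, so the pair cannot be ordered. Compound 3 `Cc1ccc(S(=O)(=O)N(Cc2cccc(F)c2F)Cc2cn(S(=O)(=O)c3ccc(F)cc3)c3ccccc23)cc1` has not yet been measured in this assay. It differs from compound 2 in one place: methyl in place of fluoro on an aromatic carbon. Cut one bond further out, the change reads (4-fluorophenyl)sulfonyl to (4-methylphenyl)sulfonyl. Within the data shown here, no step between measured compounds covers this change. Compound 1 carries the methyl on both such rings and compound 2 the fluoro on both, and their two values lie within the scatter of each other, so for this assay no step beyond the scatter is expected in either direction. Compound 3 is expected to give about -17%, between -35% and 3%, which amounts to an expected step of a number 3 percentage points higher from compound 2 to compound 3 (within the scatter).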

Compound 3, a percentage reported as inhibition, at one concentration (the size of the read-out at that concentration, not a potency): -35%
For compound 3 the middle estimate is 18 percentage points above the measured one; measured number inside the range.
By their numbers in this assay, from the lowest: compound 3; then compounds 2 and 1 (each within the scatter of the next).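

In this assay the exchange reads differently depending on which ring carries it: methyl in place of fluoro gives a number 15 percentage points lower from compound 2 to compound 3 (beyond the scatter) and fluoro in place of methyl on the other arylsulfonyl ring gives a number 21.1 percentage points lower from compound 1 to compound 3 (beyond the scatter) as well. Each single exchange therefore leads to compound 3, which carries one (4-fluorophenyl)sulfonyl and one (4-methylphenyl)sulfonyl, so this substituent does register at this position, although compound 1 and compound 2, which differ in two places, could not be ordered. Nothing available bears on the reason for this result.

Open, from the compounds shown here alone, is whether the low number belongs to this exact arrangement or would also appear with methyl and fluoro swapped between the two rings. Also open, going by these compounds, is how an amine or a methoxy group on this aromatic carbon would read.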